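The source may report more compounds than this note shows. Statements on the series, on what has been measured and on what is new or still open speak of the compounds shown alone.

Compound 3 `COc1cc(/C=C/C(=O)c2cccc(N)c2)ccc1O` carries a free amino group on its aromatic ring. In a functional assay on HUVEC cells (Homo sapiens) for inhibition, tested at 2.5 ug/mL (on this read-out higher numbers stand for a stronger effect at the one concentration tested and lower numbers for a weaker effect), compound 3 gives 20%, the lowest of the three numbers in hand. The two acylated analogues sit well above it: compound 1 `COc1cc(/C=C/C(=O)c2cccc(NC(=O)c3c(Cl)cccc3Cl)c2)ccc1O` gives 53% and compound 2 `COc1cc(/C=C/C(=O)c2cccc(NC(=O)c3ccco3)c2)ccc1O` gives 61%; the difference between them is a number 8 percentage points higher from compound 1 to compound 2 (within the scatter). Removing the acyl group cost a number 33 percentage points lower from compound 1 to compound 3 (beyond the scatter) and a number 41 percentage points lower from compound 2 to compound 3 (beyond the scatter), so both steps point the same way and are large. Compound 4 `COc1cc(/C=C/C(=O)c2cccc(NC(=O)c3ccc(Cl)cc3Cl)c2)ccc1O` re-installs an acyl group: (2,4-dichlorophenyl)carbonyl in place of hydrogen on a nitrogen on an aromatic ring. Since compound 1 gives 53% with a related dichlorophenyl group, compound 4 is expected to regain roughly that level, a step of a number 35 percentage points higher from compound 3 to compound 4 (beyond the scatter). Compound 4 is therefore estimated at 55%, within 35% to 75%.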

Compound 4, a percentage reported as inhibition, at one concentration (the size of the read-out at that concentration, not a potency): 29%
Compound 4: the middle estimate sits 26 percentage points above what was measured; the measured number lies below the stated range.
By their numbers in this assay, from the lowest: compounds 3 and 4 (each within the scatter of the next); then compounds 1 and 2 (each within the scatter of the next).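

In this assay, acylating the nitrogen does not by itself restore the number: the (2,4-dichlorophenyl)carbonyl group gives only a number 9 percentage points higher from compound 3 to compound 4 (within the scatter). The outcome depends on the acyl group, with a number 24 percentage points lower from compound 1 to compound 4 (beyond the scatter) between the two dichlorophenyl isomers and a number 32 percentage points lower from compound 2 to compound 4 (beyond the scatter) on replacing furan-2-yl. No measured evidence bears on the origin of this dependence.

Going by these compounds, whether an unsubstituted phenyl or a single chlorine on the phenyl ring would track compound 1 or compound 4 remains open. Also open, on these data alone, is whether a saturated acyl group, such as acetyl, would hold the number.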